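The compounds below may be only part of what the source reports. "The series", "measured", "known", "first", "only" and "open" are said of these compounds alone.

Measured so far:
Compound 1 `C(#Cc1nc2c(s1)CN(C1CCCCC1)CC2)c1ccccc1`: in an assay on HEK293 cells for negative allosteric modulation of metabotropic glutamate receptor 5 (Homo sapiens), read by FLIPR, with a stated time of 1 h (on this read-out higher numbers stand for weaker inhibition and lower numbers for stronger inhibition), compound 1 gives > 10000 nM, which is a limit of the assay and not a number.
Compound 2 `O=C(C1CCC1)N1CCc2nc(C#Cc3ccccc3)sc2C1`: in this assay compound 2 gives 370 nM.

Among the compounds with values here, compound 2 thus holds the only number in this assay; the other value shown is a limit (the limit of > 10000 nM in this assay, at which 1 of the 2 values shown sits). Within the data shown here, the single measured step, an at least 27-fold lower number from compound 1 to compound 2 (1.43 log units; beyond the scatter), changes what the amine nitrogen in the ring carries and turns the amine into an amide.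

Compound 3 `O=C(C1CCCO1)N1CCc2nc(C#Cc3ccccc3)sc2C1` differs from compound 2 in oxolan-2-yl in place of cyclobutyl on a carbonyl carbon. The carbonyl and the amide-type nitrogen in the ring are kept; only the ring attached to the carbonyl carbon is exchanged. Among the measured compounds shown here, no measured step touches this part of compound 2, so the step from compound 1 to compound 2 bears on it only loosely, in that an amide carrying a small ring gave a number where the cyclohexyl amine gave a limit. For compound 3 the expected step in this assay is therefore a 1.4-fold higher number from compound 2 to compound 3 (0.13 log units; within the scatter), which is not beyond the scatter in either direction. Compound 3 is estimated at 500 nM, with a range from 150 nM to 2000 nM.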

Compound 3, half-maximal inhibitory concentration: > 10000 nM
Compound 3: only a limit was reported (the forecaster's own chance of this, stated with the estimate: 10%); at least 20-fold (1.30 log units) between middle value and limit.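

In this assay, the group on a carbonyl carbon whose other neighbour is the amide-type nitrogen in a ring proves to be a sensitive position: oxolan-2-yl in place of cyclobutyl gives an at least 27-fold higher number from compound 2 to compound 3 (1.43 log units; beyond the scatter). The carbonyl and the amide-type nitrogen are both kept in this exchange, so the amide alone is not enough to give a number, and the ring on the carbonyl carbon decides the outcome among the compounds shown. The value of compound 3 is a limit, as is that of compound 1, so the step between these two cannot be read and they stay unranked: the limit of > 10000 nM in this assay, at which 2 of the 3 values shown sit.

The exchange swaps a four-membered carbon ring for a five-membered ring with one hetero atom, so ring size and the ring oxygen change together and the compounds shown do not tell these two apart. Cyclopentyl or oxetan-2-yl on the same carbonyl carbon would separate the two, and it remains open whether an open chain such as isopropyl there would give a number in this assay.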